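Aryl sulfonamide variation on the shared core

This account rests on a few compounds, and the source may have more. Where it says the series, first, only, none or still open, it means among the compounds named here.

Compound 1 `CC(=O)N(C)c1ccc2[nH]c(-c3n[nH]c4ccccc34)cc2n1` reaches only the limit of the assay, > 50000 nM, in a functional assay on A549 cells (Homo sapiens) for antiproliferative activity, read by MTT assay, with a stated time of 72 h; a lower number here means a stronger inhibitor, a higher number a weaker inhibitor; that limit is the limit of > 50000 nM in this assay, at which 1 of the 3 values shown sits. Compound 2 `Cc1ccc(S(=O)(=O)N(C)c2ccc3[nH]c(-c4n[nH]c5ccccc45)cc3n2)cc1` gives 27100 nM in this assay, and compound 3 `CN(c1ccc2[nH]c(-c3n[nH]c4ccccc34)cc2n1)S(=O)(=O)c1ccc(Cl)cc1` gives 18200 nM. The steps of an at least 1.8-fold lower number from compound 1 to compound 2 (0.26 log units; that floor lies within the scatter) and an at least 2.7-fold lower number from compound 1 to compound 3 (0.43 log units; beyond the scatter) both start from a limit, so their true size is open. The two numbers from compound 2 and compound 3 lie within the scatter of each other, so neither stands apart. Compound 4 `COc1ccc(S(=O)(=O)N(C)c2ccc3[nH]c(-c4n[nH]c5ccccc45)cc3n2)cc1OC` differs from compound 3 by 3,4-dimethoxyphenyl in place of 4-chlorophenyl on a sulfonyl sulfur. Within the data shown here, the only measured step that bears on this, a change on the same aryl ring, is a 1.5-fold lower number from compound 2 to compound 3 (0.17 log units; within the scatter), within the scatter. For compound 4 the expected step is therefore a 1.2-fold higher number from compound 3 to compound 4 (0.08 log units; within the scatter), none beyond the scatter. Compound 4 is estimated at 22000 nM, between 7000 nM and 60000 nM.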

Compound 4, half-maximal inhibitory concentration: > 50000 nM
Compound 4: no number, only a limit (the forecaster's own chance of this, stated with the estimate: 25%); middle value at least 2.2-fold (0.35 log units) from the limit.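

3,4-Dimethoxyphenyl in place of 4-chlorophenyl on the sulfonyl sulfur gives an at least 2.7-fold higher number from compound 3 to compound 4 (0.43 log units; beyond the scatter), the first change on this aryl ring that goes beyond the scatter in this assay. Against 4-methylphenyl, the same group gives an at least 1.8-fold higher number from compound 2 to compound 4 (0.26 log units; that floor lies within the scatter), so the size of that step stays open. Compound 4 gives only a limit of the assay, as compound 1 does: the limit of > 50000 nM in this assay, at which 2 of the 4 values shown sit.

How far compound 4 lies past that limit is open. Also open, going by these compounds, is whether a single methoxy group, an amine or a carboxylic acid on this aryl ring would keep a value like those of compound 2 and compound 3.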